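The source may hold more compounds than are shown below. What is called first, only, known or untested is meant among the compounds shown, and "the series" means these compounds.

Values in a functional assay on blood (Homo sapiens) for inhibition; a lower number here means a stronger inhibitor, a higher number a weaker inhibitor:
- Compound 1 `Oc1ccc(OCc2ccc3ccccc3n2)cc1C1(c2ccccc2)CC2CCC1C2`: 580 nM
- Compound 2 `COC(=O)COc1ccc(OCc2ccc3ccccc3n2)cc1C1(c2ccccc2)CC2CCC1C2`: 290 nM
- Compound 3 `O=C(O)COc1ccc(OCc2ccc3ccccc3n2)cc1C1(c2ccccc2)CC2CCC1C2`: > 3000 nM, a limit

Compound 3 stands at the limit of > 3000 nM in this assay, at which 1 of the 3 values shown sits; this is a limit, not a number.

Compound 4 `CCOC(=O)CCCOc1ccc(OCc2ccc3ccccc3n2)cc1C1(c2ccccc2)CC2CCC1C2` has 2-(ethoxycarbonyl)ethyl in place of carboxy on a saturated chain carbon bound to an oxygen on an aromatic ring. Within the data shown here, the closest precedent is the large at least 10-fold higher number from compound 2 to compound 3 (1.01 log units; beyond the scatter), which runs in the opposite sense, from ester to carboxy. The step of an at least 5.1-fold higher number from compound 1 to compound 3 (0.71 log units; beyond the scatter) is also beyond the scatter, whereas a 2.0-fold lower number from compound 1 to compound 2 (0.30 log units; within the scatter) lies within it. Among the measured compounds shown here, no measured compound carries the longer chain, so the range is kept wide. A clear move to a lower number is expected, with the estimated step being an at least 7.5-fold lower number from compound 3 to compound 4 (0.87 log units; beyond the scatter). Compound 4 is estimated at 400 nM, with an expected range of 120 nM to 1300 nM.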

Compound 4, half-maximal inhibitory concentration: 150 nM
The estimate for compound 4 lay 2.7-fold (0.43 log units) above the measured number; the range from low to high includes it.
By their numbers in this assay, from the lowest: compounds 4, 2 and 1 (each within the scatter of the next, the first and the last beyond it). At a limit, above all of these: compound 3.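

In this assay, 3-(ethoxycarbonyl)propyl on the oxygen on an aromatic ring does not separate from the shorter ester: a 1.9-fold lower number from compound 2 to compound 4 (0.29 log units; within the scatter). Yet this longer ester, unlike the shorter one, clears the scatter against the hydrogen of compound 1: a 3.9-fold lower number from compound 1 to compound 4 (0.59 log units; beyond the scatter). A second ester also stands well clear of carboxymethyl, although compound 3 gives only a limit: an at least 20-fold lower number from compound 3 to compound 4 (1.30 log units; beyond the scatter).

Open, on these data alone, is whether a carboxylic acid on the longer chain falls away as compound 3 does. Also open, as far as these compounds go, is whether an amide or an amine at the chain end would hold these values.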